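The source may report more compounds than this note shows. Statements on the series, on what has been measured and on what is new or still open speak of the compounds shown alone.

In an ADME assay on S9 fraction from liver (Rattus norvegicus) for metabolic stability, with a stated time of 1 h (on this read-out higher numbers stand for a more stable compound and lower numbers for a less stable compound), two compounds sharing one core have been measured. Compound 1 `N#Cc1cnc(NCc2cnccc2C(F)(F)F)cc1N[C@H]1CC[C@@H](O)CC1` gives 6%, and compound 2 `CN(C)C(=O)[C@H]1CC[C@@H](Nc2cc(NCc3cnccc3C(F)(F)F)ncc2C#N)CC1` gives 22%, the higher of the two numbers. Compound 3 `N#Cc1cnc(NCc2cnccc2C(F)(F)F)cc1N[C@H]1CC[C@@H](n2cncn2)CC1` has not yet been measured in this assay. It keeps the core of compound 2 and differs from it in one group: 1H-1,2,4-triazol-1-yl in place of dimethylcarbamoyl on a saturated ring carbon. In words, 1H-1,2,4-triazol-1-yl stands in place of dimethylcarbamoyl on a saturated ring carbon.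

Among the measured compounds shown here, only one measured step bears on this change: a number 16 percentage points higher from compound 1 to compound 2 (beyond the scatter). That step, also on a saturated ring carbon, replaced hydroxy with dimethylcarbamoyl. It is modest, and as a single step it cannot show how the incoming 1H-1,2,4-triazol-1-yl will behave. A step of similar modest size is therefore expected, with the direction only tentatively upward and a fall not excluded. The expected change is a number 8 percentage points higher from compound 2 to compound 3 (within the scatter). The estimate for compound 3 is 30%, with an expected range from 10% to 58%.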

Compound 3, percent of the compound remaining: 44%
Compound 3: the middle estimate sits 14 percentage points below what was measured, within the range that was stated.
By their numbers in this assay, from the lowest: compound 1; then compound 2; then compound 3.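

In this assay, the amide is not the best of the groups shown on this saturated ring carbon: 1H-1,2,4-triazol-1-yl, which has no carbonyl, gives a number 22 percentage points higher from compound 2 to compound 3 (beyond the scatter), even though the two groups match in heavy-atom count, hydrogen-bond donors and net charge and differ in the aromatic ring, the hetero atoms and the hydrogen-bond acceptor count. Measured against the hydroxy group, the same replacement gives a number 38 percentage points higher from compound 1 to compound 3 (beyond the scatter), so a change at this one place, with the rest of the structure held constant, is enough to produce a large step on this read-out. No measurement given here explains why the triazole ranks highest of the three groups.

The compounds shown leave open whether this rise belongs to the 1H-1,2,4-triazol-1-yl group in particular or would also appear with another five-membered aromatic ring, such as 1H-imidazol-1-yl or 1H-pyrazol-1-yl. They also leave open how an amine or a carboxylic acid on the same ring carbon would compare, and whether the step would hold with a different arrangement of the ring substituents.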